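From 4-hydroxyphenyl to 3,5-difluorophenyl on the shared core

The source may report more compounds than this note shows. Statements on the series, on what has been measured and on what is new or still open speak of the compounds shown alone.

Measured in an ADME assay on the whole organism (Mus musculus, strain Swiss Webster) for pharmacokinetics, read by LC-MS, at a dose of 50 mg/kg by the oral route; a higher number here means more compound in the circulation at the dose given, a lower number less compound in the circulation:
Compound 1 `O=C(Nc1ccc(F)c(-c2nc3ncc(-c4ccc(F)c(F)c4)cc3[nH]2)c1)N1CCCC1`: 6670 nM
Compound 2 `O=C(Nc1ccc(F)c(-c2nc3ncc(-c4cncc(F)c4)cc3[nH]2)c1)N1CCCC1`: 1070 nM
Compound 3 `O=C(Nc1ccc(F)c(-c2nc3ncc(-c4ccc(O)cc4)cc3[nH]2)c1)N1CCCC1`: 130 nM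

Compound 3 stands lowest of the three in this assay. Compound 4 `O=C(Nc1ccc(F)c(-c2nc3ncc(-c4cc(F)cc(F)c4)cc3[nH]2)c1)N1CCCC1`, not yet measured, carries 3,5-difluorophenyl in place of 4-hydroxyphenyl on an aromatic carbon. The closest evidence is the large step of a 51-fold lower number from compound 1 to compound 3 (1.71 log units; beyond the scatter), where 4-hydroxyphenyl replaces 3,4-difluorophenyl. The modest step of an 8.2-fold lower number from compound 2 to compound 3 (0.92 log units; beyond the scatter) points the same way. Undoing such a replacement should therefore bring a large rise, although no measured compound carries 3,5-difluorophenyl itself. The expected step is a 35-fold higher number from compound 3 to compound 4 (1.54 log units; beyond the scatter). For compound 4 the estimated value is 4500 nM, with an expected range of 1500 nM to 13000 nM.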

Compound 4, maximal plasma concentration: 4800 nM
The estimate for compound 4 lay 1.1-fold (0.03 log units) below the measured number; the range from low to high includes it.
By their numbers in this assay, from the lowest: compound 3; then compound 2; then compounds 4 and 1 (each within the scatter of the next).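

In this assay the two difluorophenyl isomers stand within the scatter of each other, with a 1.4-fold lower number from compound 1 to compound 4 (0.14 log units; within the scatter), so the fluorine arrangements shown do not separate them. Compound 4 also stands clear of both other groups at this position, with a 37-fold higher number from compound 3 to compound 4 (1.57 log units; beyond the scatter) and with a 4.5-fold higher number from compound 2 to compound 4 (0.65 log units; beyond the scatter). No supporting measurement bears on why these numbers differ. The compounds shown leave open how a phenyl ring carrying an amine or a carboxylic acid would read here. They also leave open whether a single fluorine on the phenyl ring would give a similar number.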